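Swapping Nitro for Chloro on a Second Core

A few compounds are considered here, and "the series" means these few. Any claim that something is new, unique, unknown or untested is made for them only; others in the source may bear on it.

Compound 1 `Cc1nc(C#Cc2cc(C#N)cc([N+](=O)[O-])c2)cs1` and compound 2 `Cc1nc(C#Cc2cc(Cl)cc(C#N)c2)cs1` share one core and differ by a single change, (chloro in place of nitro on an aromatic carbon). In a functional assay on HEK293 cells for antagonist activity at metabotropic glutamate receptor 5 (Rattus norvegicus), read by calcium flux (on this read-out higher numbers stand for weaker inhibition and lower numbers for stronger inhibition), compound 1 gives 2.63 nM, and compound 2 gives 1.61 nM, which is a 1.6-fold lower number from compound 1 to compound 2 (0.21 log units; within the scatter). Compound 3 `Cc1ccc(C#Cc2cc(C#N)cc([N+](=O)[O-])c2)nc1` is built on a different core; the difference between the two cores is not broken down here. In this assay compound 3 gives 2.64 nM. Compound 4 `Cc1ccc(C#Cc2cc(Cl)cc(C#N)c2)nc1` has not yet been measured and differs from compound 3 by chloro in place of nitro on an aromatic carbon. This is the same kind of change as in the first pair, though here the chloro sits meta to a group of 9 heavy atoms rather than meta to a group of 8 heavy atoms. A similar small step is expected, a 1.6-fold lower number from compound 3 to compound 4 (0.19 log units; within the scatter), because the earlier step was a 1.6-fold lower number from compound 1 to compound 2 (0.21 log units; within the scatter). Compound 4 is therefore estimated at 1.7 nM, between 0.8 nM and 3.5 nM.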

Compound 4, half-maximal inhibitory concentration: 1.22 nM
Compound 4: the middle estimate sits 1.4-fold (0.14 log units) above what was measured, within the range that was stated.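

In this assay, chloro in place of nitro gives a 2.2-fold lower number from compound 3 to compound 4 (0.34 log units; beyond the scatter), a modest step. Set beside the step on the first core, the two do not differ by more than the scatter: the same change on two cores in this assay, a 1.6-fold lower number (0.21 log units; within the scatter) from compound 1 to compound 2 and a 2.2-fold lower number (0.34 log units; beyond the scatter) from compound 3 to compound 4, 1.3-fold (0.12 log units) apart, within the scatter of two such steps. This shows that the change behaved alike on these two cores, but the step on the first core alone lies within the scatter, and two pairs cannot show that it would carry over to any further core or explain why the numbers move.

As far as these compounds go, it stays open what an amine, a methoxy group or a carboxylic acid in place of nitro on that aromatic carbon would give. Also open, from the compounds shown here alone, is how chloro would behave on other cores.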